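The source may hold more compounds than are shown below. What is called first, only, known or untested is meant among the compounds shown, and "the series" means these compounds.

Compound 1 `C=C[C@@](C)(/C=C/c1ccc(O)c(/C=C/C#N)c1)CCC=C(C)C` is one of three measured compounds. In a functional assay on HepG2 cells (Homo sapiens) for cytotoxicity, with a stated time of 72 h (a lower number here means that less compound is needed, a higher number that more compound is needed for the effect), compound 1 gives > 52000 nM, which is a limit of the assay rather than a number.
Compound 2 `C=C[C@@](C)(/C=C/c1ccc(O)c(/C=C/C(=O)OCC)c1)CCC=C(C)C` comes next. In this assay compound 2 gives > 52000 nM, again only a limit.
Compound 3 `C=C[C@@](C)(/C=C/c1ccc(O)c(/C=C/C(N)=O)c1)CCC=C(C)C` is the third. In this assay compound 3 gives > 52000 nM, likewise a limit.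

Compound 1 therefore stands at the limit of this assay, with no number of its own. Because every value sits at the limit of > 52000 nM in this assay, at which 3 of the 3 values shown sit, the three measured steps are unreadable: a step that the two limits leave unreadable from compound 1 to compound 2, a step that the two limits leave unreadable from compound 1 to compound 3 and a step that the two limits leave unreadable from compound 2 to compound 3. All three concern the substituent on the double-bonded chain carbon bound to a double-bonded chain carbon, or the group on the carbonyl carbon within it.

Compound 4 `COc1ccc(/C=C/[C@@](C)(/C=C/c2ccc(O)c(/C=C/C#N)c2)CCC=C(C)C)cc1` differs from compound 1 elsewhere: 2-(4-methoxyphenyl)ethenyl in place of vinyl on a saturated chain carbon bound to a double-bonded chain carbon and two saturated chain carbons. Among the compounds with values here, no measured step alters this part of the shared core, so none of them bears on the step from compound 1 to compound 4, and their unreadable sizes give no direction. Within the data shown here, the only guidance is that compound 1 and its two relatives all sit at the limit of this assay.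

On that basis compound 4 is expected to remain near the limit, with an estimated value of 60000 nM and a range from 15000 nM to 200000 nM. The step that the limit leaves unreadable from compound 1 to compound 4 is thus expected to be no more than the scatter, if it can be read at all.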

Compound 4, half-maximal effective concentration: > 26000 nM
Compound 4: no number, only a limit; the forecaster's own chance of this, stated with the estimate: 65%; the middle value does not contradict the limit.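

In this assay compound 4 gives > 26000 nM, which is again only a limit and not a number. Compound 1 also stands at a limit, so the step between compound 1 and compound 4 cannot be read. The compounds shown leave open whether 2-(4-methoxyphenyl)ethenyl in place of vinyl changes the result in this assay at all.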